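Trimming a Bromobenzyl Ether Down to Fluorine

A few compounds are considered here, and "the series" means these few. Any claim that something is new, unique, unknown or untested is made for them only; others in the source may bear on it.

The study concerns inhibitors examined in an assay for inhibition of Amine oxidase [flavin-containing] A (Homo sapiens), read by fluorescence, with a stated time of 20 min; a lower number here means a stronger inhibitor, a higher number a weaker inhibitor. Compound 1 `O=C(c1ccc(OCCCN2CCCCC2)cc1)C1CC1` is the simpler of the two measured structures. In this assay compound 1 reaches only the limit > 50000 nM, a boundary of the measurement rather than a number. Compound 1 thus sits at the limit of > 50000 nM in this assay, at which 1 of the 2 values shown sits. Compound 2 `O=C1/C(=C/c2ccc(OCCCN3CCCCC3)cc2)Cc2cc(OCc3ccc(Br)cc3)ccc21` carries the (4-bromobenzyl)oxy group on its fused core. In this assay compound 2 likewise gives only the limit > 10000 nM, again a boundary and not a measured value. Compound 2 therefore stands at the limit of > 10000 nM in this assay, at which 1 of the 2 values shown sits, and no number for it is known at all.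

Compound 3 `O=C1/C(=C/c2ccc(OCCCN3CCCCC3)cc2)Cc2cc(F)ccc21` differs from compound 2 by fluoro in place of (4-bromobenzyl)oxy on an aromatic carbon, in words fluoro in place of (4-bromobenzyl)oxy on an aromatic carbon. For the measured compounds named here, no step between measured compounds is available to gauge such a change, so its size cannot be read from the data. The expectation for compound 3 is that it stays weak, most likely again at a limit, with an estimated value of 30000 nM and a range from 5000 nM to 150000 nM. The expected step is a step that the limit leaves unreadable from compound 2 to compound 3, in no direction beyond the scatter.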

Compound 3, half-maximal inhibitory concentration: 9180 nM
Compound 3: middle estimate off by 3.3-fold (0.51 log units), on the high side; low and high end bracket the measured number.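

With fluoro in place of (4-bromobenzyl)oxy on an aromatic carbon, compound 3 gives 9180 nM in this assay, the only actual number among the compounds shown, so this position can carry a small substituent and still yield a reading inside the range of the assay. Compound 2 stands only at a limit, which sets how much can be said of the change: the limit of > 10000 nM in this assay, at which 1 of the 3 values shown sits. The change therefore reads as an at least 1.0-fold lower number from compound 2 to compound 3 (0.03 log units; that floor lies within the scatter), and that floor means the data allow anything from almost no gain to a large one on losing the bromobenzyl ether, while the number for compound 3 itself still marks a weak inhibitor.

As far as these compounds go, what remains open is the true size of the step, and whether it follows from the loss of the large ether or from the fluorine itself. A simple methoxy group or a plain benzyloxy group without bromine at this same aromatic carbon, set on the shared core, would help to separate the contribution of the terminal bromine from that of the whole benzyl ether.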